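This account rests on a few compounds, and the source may have more. Where it says the series, first, only, none or still open, it means among the compounds named here.

Of the compounds shown here, three of one series have been measured in a functional assay, read by spectrophotometry, with a stated time of 30 min; a lower number here means a stronger inhibitor, a higher number a weaker inhibitor. Compound 1, `Cc1cccc(NNC(=O)CC[C@H](N)C(=O)O)c1`, gives 10.1 ug/mL in this assay. Compound 2, `N[C@@H](CCC(=O)NNc1cccc(F)c1)C(=O)O`, gives 11.4 ug/mL in this assay. Compound 3, `Cc1ccc(NNC(=O)CC[C@H](N)C(=O)O)cc1`, gives 9.99 ug/mL in this assay. The three numbers lie close together, and none of the three stands apart from the others by more than the usual scatter.

Compound 1 and compound 2 differ in one place: fluoro in place of methyl on an aromatic carbon. The step that goes with this change is a 1.1-fold higher number from compound 1 to compound 2 (0.05 log units; within the scatter). Compound 1 and compound 3 are built from the same atoms joined differently; the difference between the two cores is not broken down here.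

Compound 4, `N[C@@H](CCC(=O)NNc1ccc(F)cc1)C(=O)O`, has not yet been measured. It differs from compound 3 in one place: fluoro in place of methyl on an aromatic carbon. Among the compounds with values here, this is the same kind of change as the one from compound 1 to compound 2, though not the same: in the measured pair the place is meta to a large group, whereas in compound 4 the place is para to a large group.

Because the one measured occurrence of this change gave a 1.1-fold higher number from compound 1 to compound 2 (0.05 log units; within the scatter), the step from compound 3 to compound 4 in this assay is expected to be small as well, roughly a 1.1-fold higher number from compound 3 to compound 4 (0.04 log units; within the scatter). On that basis compound 4 is estimated to give 11 ug/mL in this assay, with a likely range from 7 ug/mL to 17 ug/mL.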

Compound 4, half-maximal inhibitory concentration: 13.8 ug/mL
Compound 4: the middle estimate sits 1.3-fold (0.10 log units) below what was measured; low and high end bracket the measured number.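

In this assay, putting fluoro in place of methyl on an aromatic carbon, para to a large group, gives a 1.4-fold higher number from compound 3 to compound 4 (0.14 log units; within the scatter). Set beside the earlier occurrence of this change, the new step shows no difference between the two cores that can be told from the scatter: the same change on two cores in this assay, a 1.1-fold higher number (0.05 log units; within the scatter) from compound 1 to compound 2 and a 1.4-fold higher number (0.14 log units; within the scatter) from compound 3 to compound 4, 1.2-fold (0.09 log units) apart, within the scatter of two such steps. Within the data shown here, this shows only that the change moved the number little on these two cores, so that in this small set a step read on one core was a fair guide to the step on the other; it does not show that the change is without consequence in general, and with just two pairs, which differ both in their core and in where the change sits, it cannot separate the influence of the core from that of the place.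

All four compounds carry only methyl or fluoro on the aromatic ring, and all share the same chain and the same end bearing the amine and the carboxylic acid. Open, then, is how this assay would respond to a larger ring group such as methoxy or trifluoromethyl, to a longer chain, or to an ester in place of the carboxylic acid.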